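Trifluoromethyl in place of methoxy on the aryl ring

The compounds below may be only part of what the source reports. "The series", "measured", "known", "first", "only" and "open" are said of these compounds alone.

Compound 1 `Nc1c(-c2ccccc2)nc2ccccn12` is the unsubstituted amine of the shared core. In an assay on membranes from brain for displacement of a labelled ligand from adenosine receptor A1 (Rattus norvegicus) (on this read-out lower numbers stand for stronger inhibition and higher numbers for weaker inhibition), compound 1 gives > 100000 nM, which is a limit of the assay and not a number (the limit of > 100000 nM in this assay, at which 1 of the 3 values shown sits). Compound 2 `COc1ccc(-c2nc3ccccn3c2NC2CCCCC2)cc1` carries a cyclohexyl on the amine and a methoxy on the six-membered aromatic ring of carbon only; in this assay compound 2 gives 7610 nM. Compound 3 `Oc1ccc(-c2nc3ccccn3c2NC2CCCCC2)cc1` carries hydroxy in its place, and in this assay compound 3 gives 5530 nM. Of the two numbers shown, compound 2 and compound 3 lie within the scatter of each other, the step of a 1.4-fold lower number from compound 2 to compound 3 (0.14 log units; within the scatter) being small; compound 1 sits apart at its limit.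

The change to compound 4 `FC(F)(F)c1ccc(-c2nc3ccccn3c2NC2CCCCC2)cc1` is trifluoromethyl in place of methoxy on an aromatic carbon. For the measured compounds named here, the only measured step at this position is the methoxy-to-hydroxy step a 1.4-fold lower number from compound 2 to compound 3 (0.14 log units; within the scatter), which stayed within the scatter, and no measured compound carries trifluoromethyl. On that basis no shift beyond the scatter in this assay is expected in either direction, with a wide margin. Compound 4 is therefore estimated at about 6000 nM, in a range of 1500 nM to 25000 nM. The expected step of a 1.3-fold lower number from compound 2 to compound 4 (0.10 log units; within the scatter) is correspondingly modest.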

Compound 4, inhibition constant: > 100000 nM
Compound 4 gave a limit, no number; the forecaster's own chance of this, stated with the estimate: 10%; middle value at least 16-fold (1.22 log units) away from the limit.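

In this assay this position no longer looks indifferent to the group it carries, as the methoxy-to-hydroxy step a 1.4-fold lower number from compound 2 to compound 3 (0.14 log units; within the scatter) alone suggested: trifluoromethyl in place of methoxy gives an at least 13-fold higher number from compound 2 to compound 4 (1.11 log units; beyond the scatter), and trifluoromethyl in place of hydroxy gives an at least 18-fold higher number from compound 3 to compound 4 (1.25 log units; beyond the scatter). Compound 4 gives > 100000 nM, which is a limit of the assay and not a number. Of the three groups shown on this aromatic carbon, methoxy and hydroxy keep a measurable value while trifluoromethyl, the only one without oxygen, does not, and the series now shows a ceiling at this end: the limit of > 100000 nM in this assay, at which 2 of the 4 values shown sit.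

The compounds shown leave open whether the result follows from the absence of oxygen on this carbon or from trifluoromethyl itself, a question that a methyl, a chlorine or an amine at the same place would help to separate. Also open, going by these compounds, are how far compound 4 lies past its limit and whether the same change has the same outcome with a longer chain in place of the cyclohexyl on the amine.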